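A few compounds are considered here, and "the series" means these few. Any claim that something is new, unique, unknown or untested is made for them only; others in the source may bear on it.

Of the compounds shown here, three that share one core have been measured in an ADME assay on HEK293 cells (Homo sapiens) for inhibition, read by MTT assay, with stated times of 18 h and 4 h; on this read-out higher numbers stand for weaker inhibition and lower numbers for stronger inhibition. Compound 1, `CCCCCCCCOP(=O)(O)OCCSC(=S)N1CCCC1`, gives 28300 nM in this assay. Compound 2, `CCCCCCCCOP(=O)(O)OCCSC(=S)N1CCCCC1`, differs from compound 1 only by piperidin-1-yl in place of pyrrolidin-1-yl on a thiocarbonyl carbon, and in this assay compound 2 gives 69000 nM. That change gives a 2.4-fold higher number from compound 1 to compound 2 (0.39 log units; beyond the scatter). Compound 3, `CCCCCCOP(=O)(O)OCCSC(=S)N1CCCC1`, differs from compound 1 in a different way, namely by hydrogen in place of ethyl on a saturated chain carbon, six bonds along the chain from an oxygen on an unsaturated carbon. For compound 3 this assay reports only a limit, > 100000 nM, which is the limit of > 100000 nM in this assay, at which 1 of the 3 values shown sits, and not a number. Shortening the chain thus gives an at least 3.5-fold higher number from compound 1 to compound 3 (0.54 log units; beyond the scatter).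

Compound 4, `CCCCCCOP(=O)(O)OCCSC(=S)N1CCCCC1`, has not been measured in this assay. Among the measured compounds shown here, it differs from compound 3 by piperidin-1-yl in place of pyrrolidin-1-yl on a thiocarbonyl carbon, which is the same change as the one from compound 1 to compound 2, made at the same place on the shared core. That earlier change gave a 2.4-fold higher number from compound 1 to compound 2 (0.39 log units; beyond the scatter), so the step from compound 3 to compound 4 is expected to be of a similar size, that is a step that the limit leaves unreadable from compound 3 to compound 4. Since the value of compound 3 is already a limit, compound 4 is expected to give 240000 nM in this assay, most likely again as a limit rather than a number, with an estimated range from 100000 nM to 600000 nM.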

Compound 4, half-maximal inhibitory concentration: > 100000 nM
Compound 4 ended at the assay's limit (the forecaster's own chance of this, stated with the estimate: 90%); the middle value is on the limit's open side.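

In this assay compound 4 gives > 100000 nM, which is a limit of the assay and not a number. The step from compound 3 to compound 4 cannot be read, so this result neither confirms nor rules out that piperidin-1-yl in place of pyrrolidin-1-yl has the same effect on the shorter-chain core as on the longer-chain one; the shortening of the chain can still be followed with piperidin-1-yl in place, where it gives an at least 1.4-fold higher number from compound 2 to compound 4 (0.16 log units; that floor lies within the scatter). Shortening the chain thus gives a higher number with pyrrolidin-1-yl, but with piperidin-1-y l in place the floor alone does not show a real change, and the two sizes cannot be compared:  the same change on two cores in this assay, an at least 3.5-fold higher number (0.54 log units; beyond the scatter) from compound 1 to compound 3 and an at least 1.4-fold higher number (0.16 log units; that floor lies within the scatter) from compound 2 to compound 4; the limit leaves it open whether they differ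

Some of the compounds shown give no number to work with, which restricts what can be compared in this series: the limit of > 100000 nM in this assay, at which 2 of the 4 values shown sit. Whether a longer chain on the shared core, or an open-chain amine in place of the ring, would give values clear of the limit stays open, and only such values could show how far either change carries from one core to another.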